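Permeability Across Cyclohexyl, Naphthyl and Phenoxy Analogues

The compounds below may be only part of what the source reports. "The series", "measured", "known", "first", "only" and "open" are said of these compounds alone.

Measured compounds:
compound 1 `COc1ccc(F)cc1CNCCCNc1ccnc2cc(C3CCCCC3)ccc12`: 23 10^-6 cm/s
compound 2 `COc1ccc(F)cc1CNCCCNc1ccnc2cc(-c3cccc4ccccc34)ccc12`: 237 10^-6 cm/s

In an ADME assay for permeability, using PAMPA, with a stated time of 30 min, at pH 7.4 (a higher number here means that the compound crosses the layer faster, a lower number that the compound crosses the layer more slowly), compound 2 gives 237 10^-6 cm/s, the higher of the two numbers measured. Its nearest neighbour, compound 1, gives 23 10^-6 cm/s. Among the measured compounds shown here, the only measured step is a 10-fold higher number from compound 1 to compound 2 (1.01 log units; beyond the scatter), and it is large.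

Compound 3 `COc1ccc(F)cc1CNCCCNc1ccnc2cc(Oc3ccccc3)ccc12` has not yet been measured. It differs from compound 2 in one place: phenoxy in place of naphthalen-1-yl on an aromatic carbon

For the measured compounds named here, no measured step exchanges one aromatic group for another, and no measured compound carries a phenoxy group. Going by the values given here, the one step that bears on the change is a 10-fold higher number from compound 1 to compound 2 (1.01 log units; beyond the scatter), which shows that the group at this place can move the number a long way. Compound 3 keeps a single aromatic ring where compound 2 has two fused ones, and the expectation is a move downward from compound 2, short of the measured step. Compound 3 is therefore estimated at 80 10^-6 cm/s, within 30 10^-6 cm/s to 200 10^-6 cm/s. The implied step a 3.0-fold lower number from compound 2 to compound 3 (0.47 log units; beyond the scatter) is expected to lie beyond the scatter.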

Compound 3, apparent permeability: 317 10^-6 cm/s
Estimate against measurement, compound 3: 4.0-fold (0.60 log units) below; measured number above the stated range.
By their numbers in this assay, from the lowest: compound 1; then compounds 2 and 3 (each within the scatter of the next).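

In this assay, phenoxy and naphthalen-1-yl on this aromatic carbon cannot be told apart: the exchange gives a 1.3-fold higher number from compound 2 to compound 3 (0.13 log units; within the scatter) despite the smaller group, with one aromatic ring instead of two and an oxygen that naphthalen-1-yl lacks. The large rise over cyclohexyl is therefore not confined to naphthalen-1-yl, since phenoxy in place of cyclohexyl gives a 14-fold higher number from compound 1 to compound 3 (1.14 log units; beyond the scatter) and both aromatic groups stand well clear of compound 1. No measurement is available that accounts for this result.

Going by these compounds, it remains open whether the oxygen of phenoxy contributes anything of its own, which a phenyl group bonded directly to the ring, or a cyclohexyloxy group, would separate from the effect of the aromatic ring. On these data alone, how far the number holds with an amine or a carboxylic acid on that ring also remains unknown.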